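The source may report more compounds than this note shows. Statements on the series, on what has been measured and on what is new or still open speak of the compounds shown alone.

Measured so far:
compound 1 `CCOC(=O)C1=Cc2ccccc2OC1(OCc1cc(-c2ccc(OC)cc2)no1)C(F)(F)F` — > 150000 nM (a limit)
compound 2 `CCOC(=O)C1=Cc2ccccc2OC1(OCc1cc(-c2ccc(Br)cc2)no1)C(F)(F)F` — 71700 nM

Among the compounds with values here, in a functional assay on DU-145 cells (Homo sapiens) for inhibition, read by MTT assay, with a stated time of 24 h (on this read-out lower numbers stand for stronger inhibition and higher numbers for weaker inhibition), compound 2 gives 71700 nM, which is the only number in the set so far. Compound 1 reaches only the limit of this assay, > 150000 nM. Within the data shown here, the single measured step, an at least 2.0-fold lower number from compound 1 to compound 2 (0.32 log units; beyond the scatter), is therefore bounded on one side by the limit of > 150000 nM in this assay, at which 1 of the 2 values shown sits, and its true size is not fixed.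

Compound 3 `CCOC(=O)C1=Cc2ccccc2OC1(OCc1cc(-c2ccc([N+](=O)[O-])cc2)no1)C(F)(F)F` is the next case: nitro in place of bromo on an aromatic carbon. Among the measured compounds shown here, no measured step exchanges bromo for nitro. For the measured compounds named here, the one step that exists alters the group on that same aromatic carbon, methoxy to bromo, and was at least modest in the direction of a lower number; whether nitro continues that trend, reverses it or leaves the number where it is cannot be read from two points, one of them a limit. The working expectation is therefore no change beyond the scatter from compound 2 to compound 3, a 1.0-fold lower number from compound 2 to compound 3 (0.01 log units; within the scatter), with a wide band on either side. Compound 3 is estimated at 70000 nM, with a range of 25000 nM to 150000 nM.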

Compound 3, half-maximal inhibitory concentration: > 150000 nM
Compound 3: no number, only a limit; the forecaster's own chance of this, stated with the estimate: 30%; middle value at least 2.1-fold (0.33 log units) from the limit.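

Working from the 4-bromophenyl to the 4-nitrophenyl member, this assay shows an at least 2.0-fold higher number from compound 2 to compound 3 (0.32 log units; beyond the scatter), so the earlier drop in the number on leaving methoxy for bromo does not carry over to every replacement on this aromatic carbon. Compound 3 gives > 150000 nM, which is a limit and not a number. Of the three groups seen para to a large group, only bromo gives a number, which makes compound 2 the strongest of the set, although the margin over either neighbour is fixed on one side only, and the step between the two compounds held at the limit cannot be read, because the values stop at: the limit of > 150000 nM in this assay, at which 2 of the 3 values shown sit.

On these data alone, the series therefore rests on one measured number, and it remains open whether bromo is a special case or one member of a wider set of groups on this carbon, as a chloro, an iodo or an amine there would help to show. Also open, as far as these compounds go, is whether anything elsewhere on the shared core moves the number further, for example a carboxylic acid in place of the ethyl ester.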